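Swapping the aryl group on the saturated ring of compound 1

A few compounds are considered here, and "the series" means these few. Any claim that something is new, unique, unknown or untested is made for them only; others in the source may bear on it.

Measured compounds:
- compound 1, `Cn1c(CN2CCC(c3ccc(Cl)cc3)CC2)nc2ccccc21`: 91%
- compound 2, `Cn1c(CN2CCN(c3ccc(C(F)(F)F)cn3)CC2)nc2ccccc21`: 81%
- compound 3, `Cn1c(CN2CCN(c3ccccc3F)CC2)nc2ccccc21`: 64%

All three were tested in an assay on CHO cells with metabotropic glutamate receptor 2 (Homo sapiens) as the target, read by FLIPR; a lower number here means a smaller maximal response, a higher number a larger maximal response. Among the three measured compounds, compound 1 shows the highest maximal response, with 91%. Compound 2 gives 81%, a number that lies within the usual scatter of compound 1, so the two cannot be ranked against each other. Compound 3 gives 64%, which lies beyond the scatter below compound 1.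

The next compound, compound 4, `Cn1c(CN2CCC(c3ccccc3F)CC2)nc2ccccc21`, has not yet been measured in this assay. Among the measured compounds shown here, it keeps the core of compound 1 and changes only one group: 2-fluorophenyl in place of 4-chlorophenyl on a saturated ring carbon.

For the measured compounds named here, no measured pair shares exactly this single change, so the expectation rests on the values shown. Compound 3 also bears a 2-fluorophenyl group, though on a different saturated ring, and its maximal response in this assay is the lowest of the three. Compound 4 is therefore expected to land below compound 1, and the expected step of a number 15 percentage points lower from compound 1 to compound 4 (beyond the scatter) may reach beyond the scatter. The estimate for compound 4 in this assay is 76%, with a range from 58% to 94%.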

Compound 4, largest response reached (Emax), in percent of the reference or control that the assay uses: 91%
Beside the measured number, compound 4's estimate is 15 percentage points below it; low and high end bracket the measured number.
By their numbers in this assay, from the lowest: compound 3; then compounds 2, 1 and 4 (each within the scatter of the next).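

In this assay, among the compounds shown here, placing 2-fluorophenyl where 4-chlorophenyl stood on the saturated ring carbon gives no change at the digits printed from compound 1 to compound 4 (within the scatter) and so provides the first direct reading at this position: both substituted phenyl groups give the same maximal response here, even though the halogen and its place on the phenyl ring both differ. The 2-fluorophenyl group therefore does not by itself go with a lower maximal response, since compound 3, which carries it on a different saturated ring, gives 64% while compound 4 gives 91% with the same group on the ring of compound 1. Nothing available explains why the maximal response stays the same across this swap.

Going by these compounds, with only these two groups at this ring carbon, a single swap cannot show how much change the position accepts, and it remains open whether a phenyl ring carrying a carboxylic acid or an amine, or a saturated cyclohexyl group, would hold the response. A maximal response also says nothing about the concentration needed to reach it, so two compounds that match in this read-out could still differ in that respect.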